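Compound 3 to compound 4: a new group on the shared core

This account rests on a few compounds, and the source may have more. Where it says the series, first, only, none or still open, it means among the compounds named here.

Measured in a functional assay on SW480 cells (Homo sapiens) for antiproliferative activity, read by MTT assay, with a stated time of 48 h; a lower number here means a stronger inhibitor, a higher number a weaker inhibitor:
compound 1 `CC(C)=CCC[C@]1(C)/C=C/[C@@H](OC(=O)C=C(C)C)[C@](C)(O)/C=C/C(=O)/C(CCl)=C\C1`: 390 nM
compound 2 `CC[Si](CC)(CC)C/C1=C/C[C@](C)(CCC=C(C)C)/C=C/[C@@H](OC(=O)C=C(C)C)[C@](C)(O)/C=C/C1=O`: 2690 nM
compound 3 `COCOC/C1=C/C[C@](C)(CCC=C(C)C)/C=C/[C@@H](OC(=O)C=C(C)C)[C@](C)(O)/C=C/C1=O`: 3710 nM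

Compound 3 and compound 2 lie within the scatter of each other, and only compound 1 stands apart, as a 9.5-fold higher number from compound 1 to compound 3 (0.98 log units; beyond the scatter) shows. The next compound is compound 4 `CC(C)=CCC[C@]1(C)/C=C/[C@@H](OC(=O)C=C(C)C)[C@](C)(O)/C=C/C(=O)/C(C(=O)N(C)C)=C\C1`, with the change dimethylcarbamoyl in place of (methoxymethoxy)methyl on a double-bonded ring carbon. Among the compounds with values here, no measured compound carries this group, so the measured steps bear on it only indirectly. Those steps alter the group on a saturated chain carbon bound to a double-bonded ring carbon. Two different replacements of chloro gave a 6.9-fold higher number from compound 1 to compound 2 (0.84 log units; beyond the scatter) and a 9.5-fold higher number from compound 1 to compound 3 (0.98 log units; beyond the scatter), while the step between them stayed small, at a 1.4-fold higher number from compound 2 to compound 3 (0.14 log units; within the scatter). Compound 4 has no chloro either, so no step beyond the scatter is expected in this assay, though this rests on little evidence. The expected change is a 1.2-fold lower number from compound 3 to compound 4 (0.09 log units; within the scatter). For compound 4 the estimated value is 3000 nM, with an expected range of 1000 nM to 9000 nM.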

Compound 4, half-maximal inhibitory concentration: 3300 nM
The estimate for compound 4 lay 1.1-fold (0.04 log units) below the measured number, within the range that was stated.
By their numbers in this assay, from the lowest: compound 1; then compounds 2, 4 and 3 (each within the scatter of the next).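

In this assay, dimethylcarbamoyl on the double-bonded ring carbon gives a 1.1-fold lower number from compound 3 to compound 4 (0.05 log units; within the scatter) and, set against the silicon-bearing group, a 1.2-fold higher number from compound 2 to compound 4 (0.09 log units; within the scatter) so a carbonyl-linked amide group at this position cannot be told apart from either group carried through a saturated chain carbon. Replacing chloromethyl with dimethylcarbamoyl gives an 8.5-fold higher number from compound 1 to compound 4 (0.93 log units; beyond the scatter) and this third replacement of chloromethyl leaves compound 1 with the lowest number of the four. No supporting data bear on this result.

From the compounds shown here alone, what remains open is whether the chlorine itself sets compound 1 apart or whether another small group on the saturated chain carbon, such as bromomethyl, hydroxymethyl or aminomethyl, would match it. A carboxylic acid or a primary amide at this ring carbon also remains untested among the compounds shown.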